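Shifting the chloro group: from compound 3 to compound 4

The compounds below may be only part of what the source reports. "The series", "measured", "known", "first", "only" and "open" are said of these compounds alone.

Three compounds have been measured in a functional assay on A549 cells (Homo sapiens) for cytotoxicity, read by XTT assay, with a stated time of 24 h; a lower number here means a stronger inhibitor, a higher number a weaker inhibitor:

Compound 1, `Cn1nnnc1SCC(=O)N/N=C/c1ccc(Br)cc1`: > 10000000 nM
Compound 2, `Cn1nnnc1SCC(=O)N/N=C/c1ccc(C(F)(F)F)cc1`: 6320000 nM
Compound 3, `C/C(=N\NC(=O)CSc1nnnn1C)c1ccccc1Cl`: 6320000 nM

The value of compound 1 is a limit of the assay and not a number (the limit of > 10000000 nM in this assay, at which 1 of the 3 values shown sits). Going by the values given here, the one step measured between compounds differing in a single place is an at least 1.5-fold lower number from compound 1 to compound 2 (0.19 log units; that floor lies within the scatter), a change that does not rise above the scatter. Compound 3 stands level with compound 2 at the digits shown, so the two lie within the scatter of each other; the remaining value is the limit already named.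

Compound 4, `C/C(=N\NC(=O)CSc1nnnn1C)c1cccc(Cl)c1`, has not yet been measured. It differs from compound 3 by 3-chlorophenyl in place of 2-chlorophenyl on a carbon with a double bond to nitrogen. Among the compounds with values here, no measured step concerns such a shift of a chloro group on the aryl ring; the only step available, an at least 1.5-fold lower number from compound 1 to compound 2 (0.19 log units; that floor lies within the scatter), swaps one group for another at a single position and stays within the scatter. There is thus no ground for expecting a step beyond the scatter in this assay, in either direction.

Compound 4 is therefore expected to give about 6320000 nM in this assay, with a range from 2000000 nM to 20000000 nM. The expected step is no change at the digits printed from compound 3 to compound 4 (within the scatter), which is none beyond the scatter.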

Compound 4, half-maximal inhibitory concentration: > 10000000 nM
Compound 4 gave a limit, no number; the forecaster's own chance of this, stated with the estimate: 35%; middle value at least 1.5-fold (0.19 log units) away from the limit.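

In this assay, going by these compounds alone, the change from 2-chlorophenyl to 3-chlorophenyl on a carbon with a double bond to nitrogen gives the first measured step at this place, with the same atoms joined differently: it is an at least 1.5-fold higher number from compound 3 to compound 4 (0.19 log units; that floor lies within the scatter) and so offers only a lower bound on the change. Compound 4 gives a limit and not a number, so the step is not shown to rise beyond the scatter, and its true size cannot be read. Compound 4 now shares that limit with compound 1, and this assay cannot order the two: the limit of > 10000000 nM in this assay, at which 2 of the 4 values shown sit.

The compounds shown leave open whether any other group at this place would give a number beyond the scatter of these values, for instance 4-chlorophenyl, or an aromatic ring carrying an amine or a carboxylic acid in place of the chloro group. They also leave open what a longer chain, such as ethyl, would do in place of the saturated chain carbon on that same carbon.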